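Amino in Place of Trifluoromethyl: Expecting Little Change

This account rests on a few compounds, and the source may have more. Where it says the series, first, only, none or still open, it means among the compounds named here.

Measured so far in a functional assay on DU-145 cells (Homo sapiens) for cytotoxicity, read by MTT assay, with a stated time of 72 h; on this read-out higher numbers stand for weaker inhibition and lower numbers for stronger inhibition:
compound 1 `COc1ccc(C(=O)c2cc(OC)c(OC)c(OC)c2)cc1NC(=O)/C=C/c1ccc(F)cc1`, 3900 nM
compound 2 `COc1ccc(C(=O)c2cc(OC)c(OC)c(OC)c2)cc1NC(=O)/C=C/c1ccc(C(F)(F)F)cc1`, 4300 nM

Compound 2 gives the highest of the two numbers, and its nearest neighbour is compound 1: the step of a 1.1-fold higher number from compound 1 to compound 2 (0.04 log units; within the scatter) lies within the scatter, so these two compounds cannot be told apart in this assay. Compound 3 `COc1ccc(C(=O)c2cc(OC)c(OC)c(OC)c2)cc1NC(=O)/C=C/c1ccc(N)cc1` is the next compound to be measured. Its change from compound 2 is amino in place of trifluoromethyl on an aromatic carbon. Among the measured compounds shown here, no measured step brings an amino group to this place; the only step available, a 1.1-fold higher number from compound 1 to compound 2 (0.04 log units; within the scatter), exchanged fluoro for trifluoromethyl and moved the number by less than the scatter. On that basis there is no sign of a step beyond the scatter in this assay, although the new change is of a different kind and the outlook is uncertain. Compound 3 is therefore expected to give about 4000 nM, in the range 1300 nM to 12000 nM, with the implied step a 1.1-fold lower number from compound 2 to compound 3 (0.03 log units; within the scatter) taken as within the scatter.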

Compound 3, half-maximal inhibitory concentration: 13500 nM
Estimate against measurement, compound 3: 3.4-fold (0.53 log units) below; the measured number lies above the stated range.
By their numbers in this assay, from the lowest: compounds 1 and 2 (each within the scatter of the next); then compound 3.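

Fluoro and trifluoromethyl could not be told apart, so the earlier pair gave no sign that the group on this aromatic carbon, para to a large group, matters in this assay. Amino shows that it can: a 3.1-fold higher number from compound 2 to compound 3 (0.50 log units; beyond the scatter) and a 3.5-fold higher number from compound 1 to compound 3 (0.54 log units; beyond the scatter) are both modest but beyond the scatter, which makes compound 3 the weakest inhibitor of the three. No measurement at hand explains why amino differs from the other two groups.

The compounds shown leave open whether this shift belongs to amino alone or would also appear with a related group on the same carbon, such as methylamino, dimethylamino or hydroxyl. As far as these compounds go, how a carboxylic acid or a longer chain at this place would read also remains unknown.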